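Aryl piperazine dithiocarbamates on HeLa cells

The source may report more compounds than this note shows. Statements on the series, on what has been measured and on what is new or still open speak of the compounds shown alone.

Working notes. The series shares one core, seen in compound 1 `Nc1ccccc1NC(=O)c1ccc(CSC(=S)N2CCN(C(c3ccccc3)c3ccccc3)CC2)cc1`, compound 2 `Nc1ccccc1NC(=O)c1ccc(CSC(=S)N2CCc3ccccc32)cc1` and compound 3 `Nc1ccccc1NC(=O)c1ccc(CSC(=S)N2CCN(c3ccc(F)cc3)CC2)cc1`, and is followed in a functional assay on HeLa cells (Homo sapiens) for antiproliferative activity, read by CCK-8 assay, with a stated time of 72 h, tested at 2 uM; a higher number here means a stronger effect of the compound at the concentration tested, a lower number a weaker effect. In this assay compound 1 gives 8%, compound 2 gives 38% and compound 3 gives 60.8%, the highest of the three, with compound 2 nearest and compound 1 furthest, both gaps beyond the usual scatter. Compound 4 `Nc1ccccc1NC(=O)c1ccc(CSC(=S)N2CCN(c3cnccn3)CC2)cc1` is not yet measured. It differs from compound 3 in one place: pyrazin-2-yl in place of 4-fluorophenyl on an amine nitrogen in a ring. For the measured compounds named here, no measured pair in the set shows this exchange, so any expectation rests only on the spread among the three numbers. The step that the estimate means, a number 15.8 percentage points lower from compound 3 to compound 4 (beyond the scatter), is expected to be a moderate fall beyond the scatter. For compound 4 a value of 45% is estimated, with a range from 20% to 70%.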

Compound 4, a percentage reported as inhibition, at one concentration (the size of the read-out at that concentration, not a potency): 70.4%
For compound 4 the middle estimate is 25.4 percentage points below the measured one; the measured number lies above the stated range.
By their numbers in this assay, from the lowest: compound 1; then compound 2; then compounds 3 and 4 (each within the scatter of the next).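

In this assay, the first exchange readable at this position gives a number 9.6 percentage points higher from compound 3 to compound 4 (within the scatter): pyrazin-2-yl in place of 4-fluorophenyl on the amine nitrogen in the ring. The aromatic ring of carbon only and the aromatic ring with 2 hetero atoms and 2 hydrogen-bond acceptors therefore cannot be told apart here. Nothing measured on these two groups bears on this result.

On these data alone, it remains open whether a pyridin-2-yl ring or a simple methyl group on the same nitrogen would keep this level of effect. The data also leave open whether the parity between compound 3 and compound 4 would hold as a potency.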